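Pyridin-3-yl in place of phenyl on compound 3

This account rests on a few compounds, and the source may have more. Where it says the series, first, only, none or still open, it means among the compounds named here.

Compound 3 `OCc1cn2c(c1CO)CS[C@@H]2c1ccccc1` gives 70800 nM in a functional assay on MCF7 cells (Homo sapiens) for cytotoxicity, read by MTT assay, with a stated time of 24 h (on this read-out higher numbers stand for weaker inhibition and lower numbers for stronger inhibition), the highest of the three numbers in hand. Compound 2 `Cc1c(CO)c(CO)c2n1[C@@H](c1ccccc1)SC2` gives 12200 nM in this assay, and compound 1 `Cc1c(COC(=O)NCc2ccccc2)cc2n1[C@@H](c1ccccc1)SC2` gives 8800 nM. Among the measured compounds shown here, the only step between measured compounds that differ in one place, a 5.8-fold higher number from compound 2 to compound 3 (0.76 log units; beyond the scatter), concerns hydrogen in place of methyl on an aromatic carbon and leaves the pendant ring on the saturated carbon untouched. Compound 4 `OCc1cn2c(c1CO)CS[C@@H]2c1cccnc1` differs from compound 3 by pyridin-3-yl in place of phenyl on a saturated ring carbon. For the measured compounds named here, no measured pair shows a change of this kind; the numbers for compound 1 and compound 2 concern other positions of the shared core and give no direction for the pendant ring. With nothing bearing on it, the step in this assay is expected to stay within the scatter, so the expected step is a 1.0-fold lower number from compound 3 to compound 4 (0.00 log units; within the scatter). Compound 4 is estimated at 70000 nM, with a range from 25000 nM to 200000 nM, and a real chance that only a limit is reported.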

Compound 4, half-maximal inhibitory concentration: > 200000 nM
Compound 4: no number, only a limit (the forecaster's own chance of this, stated with the estimate: 20%); middle value at least 2.8-fold (0.45 log units) away from the limit.
By their numbers in this assay, from the lowest: compounds 1 and 2 (each within the scatter of the next); then compound 3. At a limit, above all of these: compound 4.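

The pendant ring on the saturated ring carbon does bear on the read-out: pyridin-3-yl in place of phenyl gives an at least 2.8-fold higher number from compound 3 to compound 4 (0.45 log units; beyond the scatter) in this assay, at a position the earlier single-place step left untouched. The two pendant rings differ only by one ring nitrogen in place of a ring carbon, and that alone separates the pair. The step is bounded on one side only, since compound 4 gives no number and reads as a limit: the limit of > 200000 nM in this assay, at which 1 of the 4 values shown sits.

Open, from the compounds shown here alone, is how pyridin-4-yl or 4-aminophenyl on the same carbon would read in this assay, and so whether the step depends on where the ring nitrogen sits. Also open, going by these compounds, is whether pyridin-3-yl would give a step of similar size on the methyl-bearing core of compound 2.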